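The compounds below may be only part of what the source reports. "The series", "measured", "known", "first", "only" and "open" are said of these compounds alone.

In a functional assay on the whole organism with Mus musculus as the target (a lower number here means that less compound is needed, a higher number that more compound is needed for the effect), compound 1 (`CC(=O)Nc1c(C)c(C)c2c(c1C)CC(C)(C)O2`) gives > 100 mg/kg as a limit and not a number. Compound 2 (`CCC(=O)Nc1c(C)c(C)c2c(c1C)CC(C)(C)O2`) gives > 100 mg/kg as a limit too. Compound 3 (`Cc1c(C)c2c(c(C)c1Nc1ccccc1)CC(C)(C)O2`) gives > 50 mg/kg as a limit as well, so no measured number places it. Compound 4 (`Cc1c(C)c2c(c(C)c1Nc1ccc(Cl)cc1)CC(C)(C)O2`) differs from compound 3 in one place, phenyl to 4-chlorophenyl, with chloro in place of hydrogen on an aromatic carbon. The nearest measured steps are a step that the two limits leave unreadable from compound 1 to compound 3 and a step that the two limits leave unreadable from compound 2 to compound 3 while a step that the two limits leave unreadable from compound 1 to compound 2 lies further off, and none of them touches that aromatic carbon. No size can be carried over from them, so no step beyond the scatter is expected in this assay and no direction is foreseen. The estimated change is a step that the limit leaves unreadable from compound 3 to compound 4 and it remains uncertain. For compound 4 the expected value is 60 mg/kg with an estimated range from 25 mg/kg to 150 mg/kg and a real chance of only a limit in place of a number.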

Compound 4, dose for 50% inhibition: > 50 mg/kg
Compound 4 gave a limit, no number; the forecaster's own chance of this, stated with the estimate: 60%; the middle value does not contradict the limit.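

In this assay compound 4 gives > 50 mg/kg, a limit and not a number. The steps to compound 4 from compound 1, compound 2 and compound 3 cannot be read. On these data alone, whether the chloro group changes the dose needed, and what dose any of these four compounds requires, remains open.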